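This account rests on a few compounds, and the source may have more. Where it says the series, first, only, none or still open, it means among the compounds named here.

Of the compounds shown here, three have been measured in a physicochemical assay for acid dissociation. Compound 1 `c1ccc(-c2ccc3c(NCCCNCc4ccco4)ccnc3c2)cc1` gives 9.47. Compound 3 `COc1ccc(F)cc1CNCCCNc1ccnc2cc(CCc3ccccc3)ccc12` gives 9.47, no change at the digits shown, so the two together hold the highest of the three numbers, yet sit within the scatter of each other. Compound 2 `COc1ccc(Oc2ccc3c(NCCCNCc4cccc(OC)c4O)ccnc3c2)cc1` gives 9.28, a number that also lies within the scatter of the value of compound 1. Compound 4 `Cc1cc(C)cc(Cc2ccc3c(NCCCNCc4ccco4)ccnc3c2)c1` has not yet been measured in this assay; it differs from compound 1 by 3,5-dimethylbenzyl in place of phenyl on an aromatic carbon. Among the compounds with values here, with no measured step between compounds to draw on, a step of a number 0.02 log units lower from compound 1 to compound 4 (within the scatter) is expected, none beyond the scatter. Compound 4 is estimated at 9.45, in a range from 9.15 to 9.75.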

Compound 4, acid dissociation constant: 9.47
Compound 4: the middle estimate sits 0.02 log units below what was measured, and the stated range covers the measured number.
By their numbers in this assay, from the lowest: compounds 2, 1, 3 and 4 (each within the scatter of the next).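

In this assay, the exchange of phenyl for 3,5-dimethylbenzyl on an aromatic carbon gives no change at the digits printed from compound 1 to compound 4 (within the scatter). Within the data shown here, this is the first reading of a single change at this position, and the larger group, with 9 heavy atoms against 6, leaves the number within the scatter. Nothing on hand gives a reason for this result.

Compounds 1 and 4 carry only groups of carbon at this position. As far as these compounds go, whether an amine or a carboxylic acid placed there would also leave the number within the scatter remains open.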